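Butyl for Propyl on a Second Scaffold

A few compounds are considered here, and "the series" means these few. Any claim that something is new, unique, unknown or untested is made for them only; others in the source may bear on it.

Compound 1 `CCCCNS(=O)(=O)c1ccc(Nc2ncc3c(n2)N(C2CCCC2)[C@H](CC)C(=O)N3C)cc1` and compound 2 `CCCNS(=O)(=O)c1ccc(Nc2ncc3c(n2)N(C2CCCC2)[C@H](CC)C(=O)N3C)cc1` share a core carrying a sulfonamide. In a functional assay on K562 cells (Homo sapiens) for antiproliferative activity, read by CCK-8 assay, with a stated time of 72 h (on this read-out higher numbers stand for weaker inhibition of growth and lower numbers for stronger inhibition of growth), compound 1 gives 412 nM, and compound 2 gives 548 nM. The two differ by methyl in place of hydrogen on a saturated chain carbon, three bonds along the chain from a sulfonamide nitrogen, and this gave a 1.3-fold lower number from compound 2 to compound 1 (0.12 log units; within the scatter).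

Compound 3 `CCCNC(=O)c1ccc2c(ccn2-c2ncc3c(n2)N(c2ccn(C)n2)C(CC)C(=O)N3C)c1` rests on a different core; how that core differs from the core of compound 2 is not broken down here. In this assay compound 3 gives 8270 nM, the highest of the three numbers.

Compound 4 `CCCCNC(=O)c1ccc2c(ccn2-c2ncc3c(n2)N(c2ccn(C)n2)C(CC)C(=O)N3C)c1` is yet to be measured. It differs from compound 3 by methyl in place of hydrogen on a saturated chain carbon, three bonds along the chain from an amide-type nitrogen. This is the same kind of change as that from compound 2 to compound 1, not the same change: there the place was three bonds from a sulfonamide nitrogen, here it is three bonds from an amide-type nitrogen.

The step for compound 4 is expected to be about a 1.3-fold lower number from compound 3 to compound 4 (0.10 log units; within the scatter), beside a 1.3-fold lower number from compound 2 to compound 1 (0.12 log units; within the scatter), because the earlier step of a 1.3-fold lower number from compound 2 to compound 1 (0.12 log units; within the scatter) stayed small. Compound 4 is therefore estimated at 6500 nM in this assay, between 3000 nM and 14000 nM.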

Compound 4, concentration for 50% growth inhibition: 14100 nM
Compound 4: the middle estimate sits 2.2-fold (0.34 log units) below what was measured; the measured number lies above the stated range.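

In this assay the change from propyl to butyl on the core of compound 3 gave a 1.7-fold higher number from compound 3 to compound 4 (0.23 log units; within the scatter) and stays small there, as it did on the core of compound 1. With one pair on each core, this does not establish that the change would behave alike across the series, nor does it tie the outcome to any part of either core. The two steps point in opposite directions on paper, yet they cannot be told apart: the same change on two cores in this assay, a 1.3-fold lower number (0.12 log units; within the scatter) from compound 2 to compound 1 and a 1.7-fold higher number (0.23 log units; within the scatter) from compound 3 to compound 4, 2.3-fold (0.36 log units) apart, within the scatter of two such steps

The compounds shown leave open whether a longer chain than butyl, a branched chain or a chain ending in an amine would keep the step this small on either core. They also leave open how the same change would read on further cores, and whether a repeat of these pairs in this assay would hold the two steps as close as they stand here.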